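One amide group swapped, clearance still unmeasured

The compounds below may be only part of what the source reports. "The series", "measured", "known", "first", "only" and "open" are said of these compounds alone.

Compound 1 `COc1cc(C(=O)N2CCC(O)CC2)cc2nc(NCc3cccc(Cl)c3)oc12`: 21.7 mL/min/kg
Compound 2 `COc1cc(C(=O)N2CCC(O)C(C)C2)cc2nc(NCc3cncc(Cl)c3)oc12`: 40 mL/min/kg
Compound 3 `COc1cc(C(=O)N2CC(C)(CCO)OC[C@H]2C)cc2nc(N[C@H](C)c3cccc(Cl)c3)oc12`: 58.3 mL/min/kg

These values come from an ADME assay on cells (Hepatocyte, Rattus norvegicus, strain Wistar) for pharmacokinetics, read by LC-MS, with a stated time of 90 min, tested at 1 uM; a lower number here means slower removal, a higher number faster removal of the compound. Compound 3 lies within the usual scatter of compound 2, and beyond the scatter above compound 1. Compound 4 `COc1cc(C(=O)N2C[C@H](C)OC[C@@H]2CCO)cc2nc(N[C@H](C)c3cccc(Cl)c3)oc12` keeps the rest of compound 3 but carries 5-(2-hydroxyethyl)-2-methylmorpholin-4-yl in place of 2-(2-hydroxyethyl)-2,5-dimethylmorpholin-4-yl on a carbonyl carbon. For the measured compounds named here, no two measured compounds differ in only one place, so the data offer no direct guide to this change. A shift beyond the scatter is therefore not expected in this assay, and the expected 1.2-fold lower number from compound 3 to compound 4 (0.07 log units; within the scatter) is small. The estimated clearance of compound 4 is 50 mL/min/kg, with an expected range from 29 mL/min/kg to 80 mL/min/kg.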

Compound 4, clearance: 45 mL/min/kg
The estimate for compound 4 lay 1.1-fold (0.05 log units) above the measured number, within the range that was stated.
By their numbers in this assay, from the lowest: compounds 1, 2, 4 and 3 (each within the scatter of the next, the first and the last beyond it).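

For the compounds shown here, this is the first step where only one group differs, and in this assay the result is a 1.3-fold lower number from compound 3 to compound 4 (0.11 log units; within the scatter), which lies within the usual scatter. Putting 5-(2-hydroxyethyl)-2-methylmorpholin-4-yl in place of 2-(2-hydroxyethyl)-2,5-dimethylmorpholin-4-yl on a carbonyl carbon therefore leaves the two compounds indistinguishable by this measurement. No measurement shown here offers an explanation for this result.

As far as these compounds go, how the compound would behave with an amine or a carboxylic acid in place of the hydroxyl group on the 2-hydroxyethyl chain remains open. So does the effect of a longer chain at that spot.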